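The compounds below may be only part of what the source reports. "The series", "measured", "known", "first", "only" and "open" are said of these compounds alone.

Compound 1 `COc1cc(N)c(Cl)cc1NC(=O)C1CCN(Cc2ccccc2)CC1` gives 0.5 mg/kg in a functional assay on the whole organism for antagonist activity, with Mus musculus as the target; a lower number here means that less compound is needed, a higher number that more compound is needed for the effect. Compound 2 `COc1cc(N)c(Cl)cc1NC(=O)C1CCN(Cc2ccsc2)CC1`, which gives 3.4 mg/kg, stands highest of the two numbers; the step of a 6.8-fold higher number from compound 1 to compound 2 (0.83 log units; beyond the scatter) is beyond the scatter. Compound 3 `COc1cc(N)c(Cl)cc1NC(=O)C1CCN(CC2CCC2)CC1` differs from compound 2 by cyclobutyl in place of thiophen-3-yl on a saturated chain carbon bound to an amine nitrogen in a ring. For the measured compounds named here, the only step that bears on this change is the one from compound 1 to compound 2, which shows that altering the group at this place shifted the dose by a modest amount; no step covers a non-aromatic ring here. The expected step of a 1.5-fold higher number from compound 2 to compound 3 (0.17 log units; within the scatter) is therefore small and upward, with wide uncertainty. Compound 3 is estimated at 5 mg/kg, between 1.5 mg/kg and 20 mg/kg.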

Compound 3, dose for half-maximal effect: > 10 mg/kg
Compound 3: a limit, no number (the forecaster's own chance of this, stated with the estimate: 10%); at least 2.0-fold (0.30 log units) between middle value and limit.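

Putting the non-aromatic cyclobutyl at this place, on a saturated chain carbon bound to an amine nitrogen in a ring, raises the dose further than thiophen-3-yl did in this assay, with an at least 2.9-fold higher number from compound 2 to compound 3 (0.46 log units; beyond the scatter) and an at least 20-fold higher number from compound 1 to compound 3 (1.30 log units; beyond the scatter). Compound 3 gives > 10 mg/kg, which is a limit of the assay and not a number. Both steps are therefore lower bounds, and their full size cannot be read: the limit of > 10 mg/kg in this assay, at which 1 of the 3 values shown sits.

The compounds shown leave open whether the loss follows the absence of an aromatic ring or the smaller ring. A cyclopentyl or cyclohexyl ring at this place would bear on that question.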